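The compounds below may be only part of what the source reports. "The series", "measured", "known", "first", "only" and "open" are said of these compounds alone.

Measured compounds:
compound 1, `COc1cc(O)ccc1N1CCN(CC(O)COc2ccc(O)c3ccccc23)CC1`: > 50000 nM
compound 2, `Oc1ccc(N2CCN(CC(O)COc3ccc(O)c4ccccc34)CC2)c(O)c1`: 20300 nM

Compound 1 gives > 50000 nM in a functional assay on DU-145 cells (Homo sapiens) for antiproliferative activity, read by MTT assay, with a stated time of 48 h (a higher number here means a weaker inhibitor, a lower number a stronger inhibitor), which is a limit of the assay rather than a number. For the measured compounds named here, compound 2 gives 20300 nM in this assay, the only number obtained. The step between them is an at least 2.4-fold lower number from compound 1 to compound 2 (0.39 log units; beyond the scatter); with the limit of > 50000 nM in this assay, at which 1 of the 2 values shown sits, its true size is not known.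

Compound 3, `COc1ccccc1N1CCN(CC(O)COc2ccc(O)c3ccccc23)CC1`, has not yet been measured. It differs from compound 2 in that (2-methoxyphenyl in place of 2,4-dihydroxyphenyl on an amine nitrogen in a ring). Two things change at once: the hydrogen on oxygen that entered from compound 1 to compound 2 becomes methyl again, and one hydroxyl leaves with nothing in its place. Going by the values given here, only the step of an at least 2.4-fold lower number from compound 1 to compound 2 (0.39 log units; beyond the scatter) bears on this; it ran toward a lower number, and the present change reverses that part of it. A higher number is therefore expected, and the expected step is a 2.5-fold higher number from compound 2 to compound 3 (0.39 log units; beyond the scatter), with a fair chance that only a limit is reported. The estimate for compound 3 is 50000 nM, within 20000 nM to 120000 nM.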

Compound 3, half-maximal inhibitory concentration: 35100 nM
The estimate for compound 3 lay 1.4-fold (0.15 log units) above the measured number; measured number inside the range.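

Taking out the 2,4-dihydroxyphenyl group and putting 2-methoxyphenyl on the ring amine nitrogen gives a 1.7-fold higher number from compound 2 to compound 3 (0.24 log units; within the scatter), so this assay does not separate compound 2 from compound 3, even though this change removes the hydroxyl groups from that ring. The other new comparison, hydrogen in place of hydroxy on an aromatic carbon, gives an at least 1.4-fold lower number from compound 1 to compound 3 (0.15 log units; that floor lies within the scatter), and this floor also shows no effect that can be read from that single hydroxyl. Compound 1 remains a limit of the assay rather than a number, so the true size of both steps that start from it is unknown: the limit of > 50000 nM in this assay, at which 1 of the 3 values shown sits.

The three compounds therefore do not show which of the substituents on this ring, if any, governs the antiproliferative read-out. From the compounds shown here alone, it remains open whether an unsubstituted phenyl, a chlorine on that ring or an amine or carboxylic acid in place of the hydroxyl would give a number clearly beyond the scatter of compound 2 and compound 3.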